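Stripping the Sulfonamide Arm: Expectations for Compound 3

This account rests on a few compounds, and the source may have more. Where it says the series, first, only, none or still open, it means among the compounds named here.

Measured so far:
compound 1 `CCCCc1ccc(CN)c(=O)n1Cc1ccc(-c2ccccc2-c2nn[nH]n2)cc1`, 20 nM
compound 2 `CCCCc1ccc(CNS(=O)(=O)c2ccc(C)cc2)c(=O)n1Cc1ccc(-c2ccccc2-c2nn[nH]n2)cc1`, 9 nM

In a functional assay (aorta) for antagonist activity, with Oryctolagus cuniculus as the target (a higher number here means a weaker inhibitor, a lower number a stronger inhibitor), compound 2 gives 9 nM, the lowest of the two numbers measured; its nearest neighbour is compound 1, which gives 20 nM. Compound 3 `CCCCc1ccc(C)c(=O)n1Cc1ccc(-c2ccccc2-c2nn[nH]n2)cc1` differs from compound 2 by hydrogen in place of ((4-methylphenyl)sulfonyl)amino on a saturated chain carbon bound to an aromatic carbon. Going by the values given here, the one measured step that bears on this change is a 2.2-fold lower number from compound 1 to compound 2 (0.35 log units; beyond the scatter), which shows that adding the sulfonyl group modestly lowered the number. Compound 3 lacks both that group and the amine it sat on, so the only guide is that taking the sulfonyl away would be expected to undo that modest gain; what a bare methyl does beyond that is not shown by any measured pair. Compound 3 is therefore expected to give a higher number, a 4.4-fold higher number from compound 2 to compound 3 (0.65 log units; beyond the scatter), plausibly somewhat weaker than compound 1. Compound 3 is estimated at 40 nM, with a range from 10 nM to 160 nM.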

Compound 3, half-maximal inhibitory concentration: 7 nM
Estimate against measurement, compound 3: 5.7-fold (0.76 log units) above; the measured number lies below the stated range.
By their numbers in this assay, from the lowest: compounds 3 and 2 (each within the scatter of the next); then compound 1.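

In this assay, the whole ((4-methylphenyl)sulfonyl)amino group on the saturated chain carbon bound to an aromatic carbon can give way to hydrogen and leave compound 2 and compound 3 level, with a 1.3-fold lower number from compound 2 to compound 3 (0.11 log units; within the scatter). The same replacement of amino by hydrogen gives a 2.9-fold lower number from compound 1 to compound 3 (0.46 log units; beyond the scatter), so compound 1, with its free amine, is the one that stands apart, and a sulfonyl group on that nitrogen is not needed to reach the number of compound 3. Nothing available explains why the bare methyl matches the far larger group.

On these data alone, what a hydroxyl, a carboxylic acid or an ethyl group would do on that same chain carbon remains open. So does whether an acetyl group on the amine nitrogen would match the (4-methylphenyl)sulfonyl group of compound 2.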